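The source may report more compounds than this note shows. Statements on the series, on what has been measured and on what is new or still open speak of the compounds shown alone.

Measured in a physicochemical assay for lipophilicity, read by HPLC; a lower number here means a more polar compound, a higher number a more lipophilic compound:
Compound 1 `COC(=O)C1(c2ccc(NC(=O)Nc3cccnc3Oc3ccccc3C(C)(C)C)cc2)CC1`: 5.1
Compound 2 `CN(C)Cc1cccc(-c2ccc(NC(=O)Nc3cccnc3Oc3ccccc3C(C)(C)C)c(F)c2)c1`: 5.5
Compound 3 `CC(C)N1CCC(COc2ccc(NC(=O)Nc3cccnc3Oc3ccccc3C(C)(C)C)c(F)c2)CC1`: 3.8

Of these three, compound 1 holds the middle place. Compound 2 lies above it beyond the scatter, and compound 3 lies below it beyond the scatter.

The next compound to be measured is compound 4 `CC(C)CN1CCC(COc2ccc(NC(=O)Nc3cccnc3Oc3ccccc3C(C)(C)C)cc2)CC1`. Its difference from compound 1 is this: (1-isobutylpiperidin-4-yl)methoxy in place of 1-(methoxycarbonyl)cyclopropyl on an aromatic carbon. Among the measured compounds shown here, the entering (1-isobutylpiperidin-4-yl)methoxy group closely resembles the group that ends the one measured step bearing on this change, a number 1.70 log units lower from compound 2 to compound 3 (beyond the scatter). That step is large and points downward. Compound 3, which carries the resembling group, reads 3.8, so it offers the nearest reference. For the measured compounds named here, no measured step links compound 3 to compound 4, however, and the comparison remains partial.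

A sizeable fall beyond the scatter is therefore expected, estimated as a number 0.90 log units lower from compound 1 to compound 4 (beyond the scatter). The estimated value for compound 4 is 4.2, with an expected range from 3.6 to 4.8.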

Compound 4, partition coefficient: 4.5
Compound 4: middle estimate off by 0.30 log units, on the low side, and the stated range covers the measured number.
By their numbers in this assay, from the lowest: compound 3; then compound 4; then compound 1; then compound 2.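

In this assay, putting (1-isobutylpiperidin-4-yl)methoxy in place of 1-(methoxycarbonyl)cyclopropyl on the aromatic carbon gives a number 0.60 log units lower from compound 1 to compound 4 (beyond the scatter) as a modest fall, even though the entering group has more heavy atoms than the one it replaces. Until now, the only measured fall to a group of this kind was a number 1.70 log units lower from compound 2 to compound 3 (beyond the scatter) with 3-((dimethylamino)methyl)phenyl as the leaving group, so the lower number now appears against two different leaving groups. Nothing measured here explains the fall.

Compound 3 and compound 4 differ in more than one place, which leaves the share of the isobutyl group on the piperidine nitrogen unsettled. Also open, as far as these compounds go, is how a methyl group on that nitrogen, or a carboxylic acid in place of the methyl ester of compound 1, would read.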